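Bromo to nitro: next step in the series

This account rests on a few compounds, and the source may have more. Where it says the series, first, only, none or still open, it means among the compounds named here.

Measured in a functional assay on HL-60 cells (Homo sapiens) for cytotoxicity, read by MTT assay; on this read-out lower numbers stand for stronger inhibition and higher numbers for weaker inhibition:
- compound 1 `O=C(/C=C/c1ccccc1)c1cc(O)ccc1O`: 5300 nM
- compound 2 `O=C(/C=C/c1ccc(Cl)cc1)c1ccccc1O`: 8300 nM
- compound 3 `O=C(/C=C/c1ccc(Br)cc1)c1ccccc1O`: 7300 nM

The three values lie within the scatter of one another, so compound 3 stands apart from neither compound 1 nor compound 2.

Next is compound 4 `O=C(/C=C/c1ccc([N+](=O)[O-])cc1)c1ccccc1O`, with nitro in place of bromo on an aromatic carbon.

Within the data shown here, one measured step bears on this change: a 1.1-fold lower number from compound 2 to compound 3 (0.06 log units; within the scatter), for bromo in place of chloro. Among the measured compounds shown here, no measured step involves a nitro group, so this guide is weak and the direction stays open. No step beyond the scatter is expected, and the estimate amounts to a 1.1-fold lower number from compound 3 to compound 4 (0.05 log units; within the scatter). For compound 4 the expected value in this assay is 6500 nM, with an estimated range of 2200 nM to 19000 nM.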

Compound 4, half-maximal inhibitory concentration: 5800 nM
Compound 4: middle estimate off by 1.1-fold (0.05 log units), on the high side, and the stated range covers the measured number.
By their numbers in this assay, from the lowest: compounds 1, 4, 3 and 2 (each within the scatter of the next).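

In this assay, nitro on the aromatic carbon para to a large group stays within the scatter of bromo (a 1.3-fold lower number from compound 3 to compound 4 (0.10 log units; within the scatter)) and of chloro (a 1.4-fold lower number from compound 2 to compound 4 (0.16 log units; within the scatter)). The position therefore tolerates a change from one heavy atom to three, with two hydrogen-bond acceptors entering, without a step beyond the scatter; the halogen swap alone could not show this. Nothing measured accounts for this result. As far as these compounds go, whether an amine or a carboxylic acid at this position would give a step beyond the scatter remains open.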